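2-Methoxyphenyl in Place of 4-Chlorophenyl: an Expected Value

This account rests on a few compounds, and the source may have more. Where it says the series, first, only, none or still open, it means among the compounds named here.

For the measured compounds named here, compound 2 `O=C(Nc1cccc(OCc2cn(-c3ccc(Cl)cc3)nn2)c1)Nc1ccc(Cl)c(C(F)(F)F)c1` gives 2490 nM in a functional assay on HepG2 cells (Homo sapiens) for inhibition, read by MTT assay, with a stated time of 72 h (a lower number here means a stronger inhibitor, a higher number a weaker inhibitor), one of only two numbers known; compound 1 `CCc1ccccc1-n1cc(COc2cccc(NC(=O)Nc3ccc(Cl)c(C(F)(F)F)c3)c2)nn1` gives 3530 nM and sits within the scatter of it: a 1.4-fold lower number from compound 1 to compound 2 (0.15 log units; within the scatter). Compound 3 `COc1ccccc1-n1cc(COc2cccc(NC(=O)Nc3ccc(Cl)c(C(F)(F)F)c3)c2)nn1` remains unmeasured and differs from compound 2 by 2-methoxyphenyl in place of 4-chlorophenyl on an aromatic nitrogen. Going by the values given here, only that single step bears on this change, and it was small. Because compound 1 with 3530 nM also carries a 2-ethylphenyl on an aromatic nitrogen, compound 3 is expected close to it, and the step of a 1.2-fold higher number from compound 2 to compound 3 (0.08 log units; within the scatter) is expected to stay within the scatter. Compound 3 is thus estimated at 3000 nM, with a range from 1200 nM to 8000 nM.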

Compound 3, half-maximal inhibitory concentration: 11300 nM
The estimate for compound 3 lay 3.8-fold (0.58 log units) below the measured number; the measured number lies above the stated range.
By their numbers in this assay, from the lowest: compounds 2 and 1 (each within the scatter of the next); then compound 3.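

In this assay, the group on the aromatic nitrogen now registers beyond the scatter: a 4.5-fold higher number from compound 2 to compound 3 (0.66 log units; beyond the scatter) with 2-methoxyphenyl in place of 4-chlorophenyl, whereas 4-chlorophenyl and 2-ethylphenyl had stayed within it. Methoxy in place of ethyl on an aromatic carbon gives a 3.2-fold higher number from compound 1 to compound 3 (0.51 log units; beyond the scatter), so this single exchange on the ring is enough to move the number. The data offer no measurement that accounts for this rise. Going by these compounds, whether a hydroxyl, an amine or an ethoxy in place of the methoxy would stay near compound 3 or return towards compound 1 remains open.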